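Thiadiazolo-fused series: aryl to phenethyl swap at the core

The source may hold more compounds than are shown below. What is called first, only, known or untested is meant among the compounds shown, and "the series" means these compounds.

Measured so far:
compound 1 `CCc1ccc(-c2nn3cc(-c4cccc(N)c4)nc3s2)cc1` — 6000 nM
compound 2 `C=C(Br)C(=O)Nc1cccc(-c2cn3nc(-c4ccc(CC)cc4)sc3n2)c1` — 2200 nM
compound 3 `Nc1cccc(-c2cn3c(-c4ccc(Cl)cc4)csc3n2)c1` — 22000 nM

In a functional assay on L1210 cells (Mus musculus) for inhibition, read by cell counting, with a stated time of 2 days (a higher number here means a weaker inhibitor, a lower number a stronger inhibitor), compound 2 gives the lowest of the three numbers. Among the measured compounds shown here, the one single-site step measured, a 2.7-fold lower number from compound 1 to compound 2 (0.44 log units; beyond the scatter), describes the acylation of the aromatic amine; compound 3 differs from compound 1 in more than one place, and its value simply sits far above both.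

The next compound, compound 4 `C=C(Br)C(=O)Nc1cccc(-c2cn3nc(CCc4ccccc4)sc3n2)c1`, keeps the acylated amine of compound 2 and changes the other end of the core: phenethyl in place of 4-ethylphenyl on an aromatic carbon. For the measured compounds named here, no measured step covers a change of this kind. The step from compound 1 to compound 2 concerns a different position and gives no guidance here, and compounds 1 and 3 do not form a single-site pair with either. The expectation therefore rests on the general observation that changes at the aryl end have not yet been probed, so a step beyond the scatter cannot be ruled out, and the direction is uncertain. A modest weakening is estimated for compound 4, that is a 2.3-fold higher number from compound 2 to compound 4 (0.36 log units; beyond the scatter), with compound 4 expected at 5000 nM in this assay, within a range of 1500 nM to 17000 nM.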

Compound 4, half-maximal inhibitory concentration: 2200 nM
Compound 4: middle estimate off by 2.3-fold (0.36 log units), on the high side; the measured number falls inside the stated range.
By their numbers in this assay, from the lowest: compounds 2 and 4 (each within the scatter of the next); then compound 1; then compound 3.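

In this assay, among the compounds shown here, phenethyl in place of 4-ethylphenyl on the aromatic carbon next to the ring nitrogen and next to the ring sulfur gives no change at the digits printed from compound 2 to compound 4 (within the scatter), the first single-site reading at this end of the core, as the earlier step concerned only the acylation of the aromatic amine. With the acylated amine held constant, the two groups have the same atoms joined differently, and this rearrangement leaves the read-out within the scatter, so at this position, for this pair, the assay does not separate a ring bearing an ethyl group from a ring carried on a chain. Nothing at hand accounts for this outcome.

Open, from the compounds shown here alone, is whether a longer chain than phenethyl, or an amine or a carboxylic acid on its phenyl ring, would also leave the number where compound 2 and compound 4 stand. Also open, going by these compounds, is whether the step seen on acylating the aromatic amine of compound 1 would hold with phenethyl at this carbon, since this pair rests on a single group swap in one acylated background.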